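Carbamate replacing the branched amide on the shared core

A few compounds are considered here, and "the series" means these few. Any claim that something is new, unique, unknown or untested is made for them only; others in the source may bear on it.

Compound 3 `CCCC(C)C(=O)Nc1ccc2nc(NC(=O)C3CCCCC3)sc2c1` stands lowest of the three in a functional assay on WI-38 VA13 cells (Homo sapiens) for cytotoxicity (on this read-out higher numbers stand for an effect only at larger amounts of compound and lower numbers for an effect already at smaller amounts), with 0.14 ug/mL. Compound 2 `CC(=O)Nc1ccc2nc(NC(=O)C3CCCCC3)sc2c1` gives 2.7 ug/mL and compound 1 `COc1ccc(C(=O)Nc2ccc3nc(NC(=O)C4CCCCC4)sc3c2)cc1` gives 4.9 ug/mL; the two are within the scatter of each other, as a 1.8-fold lower number from compound 1 to compound 2 (0.26 log units; within the scatter) shows. The steps to compound 3 are large: a 19-fold lower number from compound 2 to compound 3 (1.29 log units; beyond the scatter) and a 35-fold lower number from compound 1 to compound 3 (1.54 log units; beyond the scatter). Within the data shown here, on the carbonyl carbon in question, the 1-methylbutyl group is thus the one change among the measured compounds that moves the number beyond the scatter.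

Compound 4 `C=CCOC(=O)Nc1ccc2nc(NC(=O)C3CCCCC3)sc2c1` carries allyloxy in place of 1-methylbutyl on a carbonyl carbon. Among the measured compounds shown here, no measured compound holds an allyloxy group, so the step has no direct precedent. For the measured compounds named here, the steps that bear on it are those in which the 1-methylbutyl group enters or leaves, and both say that without it the number is higher. For compound 4 a step upward beyond the scatter is therefore expected, an 11-fold higher number from compound 3 to compound 4 (1.03 log units; beyond the scatter), because a 19-fold lower number from compound 2 to compound 3 (1.29 log units; beyond the scatter) places compounds without the 1-methylbutyl group well above compound 3. In this assay compound 4 is estimated at 1.5 ug/mL, within a range from 0.3 ug/mL to 6 ug/mL.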

Compound 4, half-maximal effective concentration: 0.58 ug/mL
Compound 4: the middle estimate sits 2.6-fold (0.41 log units) above what was measured, and the stated range covers the measured number.
By their numbers in this assay, from the lowest: compound 3; then compound 4; then compounds 2 and 1 (each within the scatter of the next).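

In this assay, allyloxy is the second group on this carbonyl carbon to move the number beyond the scatter, with a 4.7-fold lower number from compound 2 to compound 4 (0.67 log units; beyond the scatter) and an 8.4-fold lower number from compound 1 to compound 4 (0.93 log units; beyond the scatter). The low end at this position therefore no longer rests on the 1-methylbutyl group alone, although compound 3 stays lowest, with a 4.1-fold higher number from compound 3 to compound 4 (0.62 log units; beyond the scatter) as the remaining gap. The series now has an intermediate level, and nothing measured accounts for the order of these groups.

The compounds shown do not separate the oxygen of allyloxy from its double bond; a propoxy group or a straight butyl chain on the same carbonyl carbon would bear on that. Going by these compounds, how a dimethylamino group on that carbon would read also stays open.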